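Compound 2 to compound 3: acetyl to ethoxycarbonyl

This account rests on a few compounds, and the source may have more. Where it says the series, first, only, none or still open, it means among the compounds named here.

Compound 2 `CC(=O)N(C)CC#CCN1CCCC1` has no number in a functional assay on the whole organism for antagonist activity, with Mus musculus as the target (on this read-out lower numbers stand for an effect already at smaller amounts and higher numbers for an effect only at larger amounts of compound), only a limit of > 10 mg/kg. In contrast, compound 1 `CCc1nccn1CC#CCN1CCCC1=O`, which has a different structure, gives a measured value of 2.5 mg/kg in this assay.

Compound 3 `CCOC(=O)N(C)CC#CCN1CCCC1` differs from compound 2 by ethoxy in place of methyl on a carbonyl carbon, so acetyl becomes ethoxycarbonyl. Going by the values given here, no measured pair isolates this change, so the expectation remains loose. The starting point, compound 2 at > 10 mg/kg, is also a limit rather than a number. A modest expected shift toward smaller doses is the working assumption, with the estimated step of an at least 1.2-fold lower number from compound 2 to compound 3 (0.09 log units; that floor lies within the scatter). A result that again gives only a limit would not be surprising. In this assay, the estimate for compound 3 is 8 mg/kg, with an expected range of 2.5 mg/kg to 25 mg/kg.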

Compound 3, dose for half-maximal effect: > 100 mg/kg
Compound 3 was reported as a limit; the forecaster's own chance of this, stated with the estimate: 45%; middle value at least 12-fold (1.09 log units) away from the limit.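

Compound 2 and compound 3 both stand only as limits in this assay, and no step can be read between them. The compounds shown leave open how large a change ethoxy in place of methyl on a carbonyl carbon brings, and in which direction.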